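Compound 4: a difluorobenzyl amide against compound 2

The source may hold more compounds than are shown below. What is called first, only, known or untested is meant among the compounds shown, and "the series" means these compounds.

Measured so far:
compound 1 `Cc1ccc(CN(C)C(=O)c2nn(-c3ccc(F)cc3)c(OC[C@@H](O)C[C@@H](O)CC(=O)O)c2C(C)C)cc1`: 37 nM
compound 2 `CC(C)c1c(C(=O)N2CCCC2c2ccccc2)nn(-c2ccc(F)cc2)c1OC[C@@H](O)C[C@@H](O)CC(=O)O`: 14 nM
compound 3 `CC(C)c1c(C(=O)NCc2cccc(Cl)c2)nn(-c2ccc(F)cc2)c1OC[C@@H](O)C[C@@H](O)CC(=O)O`: 5.4 nM

In an assay on microsomes from liver for inhibition of 3-hydroxy-3-methylglutaryl-coenzyme A reductase (Rattus norvegicus) (a lower number here means a stronger inhibitor, a higher number a weaker inhibitor), compound 2 gives 14 nM, the second highest of the three numbers, set apart from both neighbours by a 2.6-fold lower number from compound 1 to compound 2 (0.42 log units; beyond the scatter) and a 2.6-fold lower number from compound 2 to compound 3 (0.41 log units; beyond the scatter). Compound 4 `CC(C)c1c(C(=O)N(C)Cc2ccc(F)c(F)c2)nn(-c2ccc(F)cc2)c1OC[C@@H](O)C[C@@H](O)CC(=O)O` is not yet measured. The change from compound 2 is (3,4-difluorobenzyl)(methyl)amino in place of 2-phenylpyrrolidin-1-yl on a carbonyl carbon. For the measured compounds named here, two steps bear on it. The change is close to the reverse of a 2.6-fold lower number from compound 1 to compound 2 (0.42 log units; beyond the scatter), which points toward a higher number, while a 2.6-fold lower number from compound 2 to compound 3 (0.41 log units; beyond the scatter) shows that a halogen-carrying benzyl amide gave a lower number. These pull in opposite directions, so only a small step is expected, a 1.4-fold higher number from compound 2 to compound 4 (0.15 log units; within the scatter). Compound 4 is therefore estimated at 20 nM, with a range from 7 nM to 60 nM.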

Compound 4, half-maximal inhibitory concentration: 5.7 nM
Compound 4: the middle estimate sits 3.5-fold (0.55 log units) above what was measured; measured number outside the range, below it.
By their numbers in this assay, from the lowest: compounds 3 and 4 (each within the scatter of the next); then compound 2; then compound 1.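

Compound 1 and compound 4 both carry a benzyl(methyl)amino group, yet 3,4-difluorophenyl in place of 4-methylphenyl gives a 6.5-fold lower number from compound 1 to compound 4 (0.81 log units; beyond the scatter) in this assay, so this amide type does not by itself bring the weaker number of compound 1. The open-chain group also overtakes the 2-phenylpyrrolidin-1-yl amide, with a 2.5-fold lower number from compound 2 to compound 4 (0.39 log units; beyond the scatter). With a 1.1-fold higher number from compound 3 to compound 4 (0.02 log units; within the scatter), it cannot be told apart from (3-chlorobenzyl)amino.

Nothing given here explains these steps. Still open, as far as these compounds go, is how a 3-fluorobenzyl or pyridin-3-ylmethyl group would compare on this carbonyl carbon.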